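Sulfonyl sulfur substituents: from compound 2 to compound 3

The source may report more compounds than this note shows. Statements on the series, on what has been measured and on what is new or still open speak of the compounds shown alone.

In an ADME assay on CHO cells (Cricetulus griseus) for cytotoxicity, read by MTT assay (on this read-out lower numbers stand for stronger inhibition and higher numbers for weaker inhibition), compound 2 (`NS(=O)(=O)c1cccc(-c2ccc3nccc(-c4ccncc4)c3n2)c1`) gives 2000 nM and holds the lower of the two numbers, while compound 1 (`O=S(=O)(c1cccc(-c2ccc3nccc(-c4ccncc4)c3n2)c1)N1CCC(O)CC1`) gives 8000 nM as the higher one. Compound 3 (`CS(=O)(=O)c1cccc(-c2ccc3nccc(-c4ccncc4)c3n2)c1`) differs from compound 2 by methyl in place of amino on a sulfonyl sulfur in the form of methyl in place of amino on a sulfonyl sulfur. Among the measured compounds shown here, the one measured step at this sulfur, a 4.0-fold lower number from compound 1 to compound 2 (0.60 log units; beyond the scatter) and modest, involves a different group and is weak guidance. A small rise, possibly within the scatter, is therefore expected in this assay. The expected change is a 1.8-fold higher number from compound 2 to compound 3 (0.24 log units; within the scatter) on this basis. For compound 3 the estimate is 3500 nM with an expected range of 1300 nM to 9000 nM in this assay.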

Compound 3, half-maximal inhibitory concentration: 13000 nM
The estimate for compound 3 lay 3.7-fold (0.57 log units) below the measured number; the whole stated range lies below it.
By their numbers in this assay, from the lowest: compound 2; then compounds 1 and 3 (each within the scatter of the next).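

At the sulfonyl sulfur in this assay, methyl gives a 6.5-fold higher number from compound 2 to compound 3 (0.81 log units; beyond the scatter), whereas methyl in place of 4-hydroxypiperidin-1-yl gives only a 1.6-fold higher number from compound 1 to compound 3 (0.21 log units; within the scatter). Amino in compound 2 therefore stands apart, while compound 1 and compound 3 remain within the scatter of each other despite carrying very different groups. Nothing available accounts for this separation.

Open, going by these compounds, is whether methylamino or dimethylamino on the sulfur would stay with amino or fall with compound 1 and compound 3. The compounds shown also leave open how a piperazine would behave here.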